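This account rests on a few compounds, and the source may have more. Where it says the series, first, only, none or still open, it means among the compounds named here.

In a functional assay on B16-F10 cells (Mus musculus) for cytotoxicity, read by MTT assay, with a stated time of 48 h (a higher number here means a weaker inhibitor, a lower number a stronger inhibitor), compound 1 `Fc1ccc(NC(=S)Nc2nc3ccc(F)cc3s2)cc1` gives 47700 nM.
Compound 2 `S=C(Nc1ccccc1)Nc1nc2c(Cl)cccc2s1` gives only a limit of this assay, namely > 50000 nM.
Compound 3 `Fc1ccc2nc(NC(=S)Nc3ccccc3)sc2c1` likewise gives only a limit, > 50000 nM.

Compound 1 and compound 3 differ by a single change, (fluoro in place of hydrogen on an aromatic carbon), and this change made a step of an at least 1.0-fold lower number from compound 3 to compound 1 (0.02 log units; that floor lies within the scatter). The difference between the core of compound 2 and the core of compound 3 is not broken down here. Compound 4 `Fc1ccc(NC(=S)Nc2nc3c(Cl)cccc3s2)cc1` is the counterpart of compound 2 carrying the same change, (fluoro in place of hydrogen on an aromatic carbon), so among these compounds the change occurs twice.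

Among the compounds with values here, two of the three values rest at the limit of > 50000 nM in this assay, at which 2 of the 3 values shown sit, and the one measured step barely moved off that limit. On that basis, and on the limit of compound 2, a step of an at least 1.0-fold lower number from compound 2 to compound 4 (0.01 log units; that floor lies within the scatter) is expected from compound 2 to compound 4. Compound 4 is accordingly estimated at 48000 nM in this assay, with a likely range from 25000 nM to 120000 nM, and it may well again be reported only as a limit.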

Compound 4, half-maximal inhibitory concentration: > 50000 nM
Compound 4: no number, only a limit; the forecaster's own chance of this, stated with the estimate: 65%; at least 1.0-fold (0.01 log units) between middle value and limit.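

Compound 4 gives only a limit in this assay, namely > 50000 nM. Compound 2 also gives only a limit, so no step can be read from compound 2 to compound 4. The compounds shown leave open what the change from phenyl to 4-fluorophenyl does on the core of compound 2, because the values gather at one limit: the limit of > 50000 nM in this assay, at which 3 of the 4 values shown sit.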